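This account rests on a few compounds, and the source may have more. Where it says the series, first, only, none or still open, it means among the compounds named here.

In a functional assay on KB cells (Homo sapiens) for antiproliferative activity, read by MTT assay, with a stated time of 72 h (a higher number here means a weaker inhibitor, a lower number a stronger inhibitor), compound 1 `CCOC(=O)c1cc(-c2cc(OC)c(OC)c(OC)c2)c(-c2cccc(Br)c2)s1` gives > 100000 nM, which is a limit of the assay. Among the compounds with values here, compound 2 `CCOC(=O)c1cc(-c2cc(OC)c(OC)c(OC)c2)c(-c2ccc(OC)c([N+](=O)[O-])c2)s1` reads 15800 nM, the only actual number so far. Compound 3 `CCOC(=O)c1cc(-c2cc(OC)c(OC)c(OC)c2)c(-c2ccc(OC)c(OCc3ccccc3)c2)s1` gives > 100000 nM, also a limit, and so stands at the limit of > 100000 nM in this assay, at which 2 of the 3 values shown sit.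

Compound 4 `CCOC(=O)c1cc(-c2cc(OC)c(OC)c(OC)c2)c(-c2ccc(OC)c(O)c2)s1` differs from compound 3 by hydrogen in place of benzyl on an oxygen on an aromatic ring: benzyloxy to hydroxy, with hydrogen in place of benzyl on an oxygen on an aromatic ring.

Within the data shown here, two measured steps bear on this change. The closer one is an at least 6.3-fold higher number from compound 2 to compound 3 (0.80 log units; beyond the scatter), with benzyloxy in place of nitro. The other is an at least 6.3-fold lower number from compound 1 to compound 2 (0.80 log units; beyond the scatter), with one substituted phenyl exchanged for another. Both sizes are only bounds. Removing the benzyl is expected to give a lower number in this assay, with compound 2 at 15800 nM as the nearest reference. The expected change is an at least 20-fold lower number from compound 3 to compound 4 (1.30 log units; beyond the scatter). For compound 4 the estimate is 5000 nM, with an expected range from 300 nM to 60000 nM.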

Compound 4, half-maximal inhibitory concentration: 1250 nM
Estimate against measurement, compound 4: 4.0-fold (0.60 log units) above; the range from low to high includes it.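

In this assay, hydrogen in place of benzyl on an oxygen on an aromatic ring gives an at least 80-fold lower number from compound 3 to compound 4 (1.90 log units; beyond the scatter), and this size is only a bound: the limit of > 100000 nM in this assay, at which 2 of the 4 values shown sit.

Within the data shown here, the step of a 13-fold lower number from compound 2 to compound 4 (1.10 log units; beyond the scatter) is the first read between two measured numbers and not against a limit. The step of an at least 80-fold lower number from compound 1 to compound 4 (1.90 log units; beyond the scatter), with 3-hydroxy-4-methoxyphenyl in place of 3-bromophenyl, is again only a bound.

Whether the gain belongs to the free hydroxy itself or only to the loss of the benzyl stays open, as neither an amine nor a methyl ether on that aromatic carbon stands among the compounds shown. On these data alone, the ethyl ester and the trimethoxyphenyl group are common to all four compounds, so their part in the read-out remains unknown.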